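A few compounds are considered here, and "the series" means these few. Any claim that something is new, unique, unknown or untested is made for them only; others in the source may bear on it.

Measured compounds:
Compound 1 `Cc1cc(C)n(-c2cc(=O)cc(-c3ccccc3)[nH]2)n1`: in an ADME assay on CHO cells (Cricetulus griseus) for cytotoxicity, read by MTT assay (on this read-out higher numbers stand for weaker inhibition and lower numbers for stronger inhibition), compound 1 gives > 50000 nM, a limit of the assay.
Compound 2 `Cc1cc(C)n(-c2nc(C(F)(F)F)cc(=O)[nH]2)n1`: in this assay compound 2 gives 150000 nM.
Compound 3 `O=c1cc(-c2ccccc2)nc(-n2cccn2)[nH]1`: in this assay compound 3 gives > 50000 nM, a limit of the assay.

Within the data shown here, compound 2 is the only compound of the three with a number rather than a limit, and that number lies above (the limit of > 50000 nM in this assay, at which 2 of the 3 values shown sit). Compound 4 `Cc1cc(C)n(-c2nc(-c3cccnc3)cc(=O)[nH]2)n1` has not yet been measured; it differs from compound 2 by pyridin-3-yl in place of trifluoromethyl on an aromatic carbon. Among the measured compounds shown here, with no measured step of this kind to lean on, and with the values of compound 1 and compound 3 sitting at the assay limit, a step from compound 2 to compound 4 is expected to be small, either direction or none beyond the scatter, so the expected step is a 1.5-fold lower number from compound 2 to compound 4 (0.18 log units; within the scatter). Compound 4 is therefore estimated at 100000 nM, with a range from 30000 nM to 300000 nM.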

Compound 4, half-maximal inhibitory concentration: > 50000 nM
Compound 4 gave a limit, no number; the forecaster's own chance of this, stated with the estimate: 50%; the middle value is on the limit's open side.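

In this assay, among these compounds, compound 4 gives > 50000 nM, a limit of the assay, and no step from compound 2 to compound 4 can be read. The compounds shown leave open how far pyridin-3-yl in place of trifluoromethyl shifts the value, and where compound 1, compound 3 and compound 4 truly lie.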